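The source may hold more compounds than are shown below. What is called first, only, known or untested is meant among the compounds shown, and "the series" means these compounds.

Three compounds on one shared core differ only in the group on an amide-type nitrogen. In a functional assay on T-24 cells (Homo sapiens) for antiproliferative activity, read by MTT assay, with a stated time of 48 h (on this read-out lower numbers stand for stronger inhibition and higher numbers for weaker inhibition), compound 1 (`O=C(Nc1ccccc1)Nc1cccc(CNc2nccnc2Cl)c1`), carrying phenyl, gives 19800 nM as its reading. Compound 2 (`O=C(Nc1cccc(CNc2nccnc2Cl)c1)NC1CCCCC1`), carrying cyclohexyl, reads > 40000 nM and that is a limit of the assay, not a number. Compound 3 (`Cc1ccc(NC(=O)Nc2cccc(CNc3nccnc3Cl)c2)cc1Cl`), carrying 3-chloro-4-methylphenyl, gives 7390 nM as the lower of the two true numbers in hand, and the exchange of cyclohexyl for this group produced an at least 5.4-fold lower number from compound 2 to compound 3 (0.73 log units; beyond the scatter) as its result.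

Compound 4 (`O=C(Nc1cccc(CNc2nccnc2Cl)c1)Nc1ccc(Cl)c(Cl)c1`) keeps all of this but has chloro in place of methyl on an aromatic carbon, ortho to a chloro group and para to a large group, which gives 3,4-dichlorophenyl (chloro in place of methyl on an aromatic carbon). Going by the values given here, no measured step makes this exchange directly. Among the compounds with values here, the closest guide is the exchange of phenyl for 3-chloro-4-methylphenyl, which gave a 2.7-fold lower number from compound 1 to compound 3 (0.43 log units; beyond the scatter) as a modest change, and the new exchange alters only one group on that ring. In this assay little movement is therefore expected, probably none beyond the scatter, with a slight lean towards lower numbers. The estimated step is a 1.2-fold lower number from compound 3 to compound 4 (0.09 log units; within the scatter) in this case. For compound 4 the expected value is 6000 nM with an estimated range from 2500 nM to 14000 nM for repeat measurements.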

Compound 4, half-maximal inhibitory concentration: 5210 nM
Beside the measured number, compound 4's estimate is 1.2-fold (0.06 log units) above it, and the stated range covers the measured number.
By their numbers in this assay, from the lowest: compounds 4 and 3 (each within the scatter of the next); then compound 1. At a limit, above all of these: compound 2.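

In this assay, chloro in place of methyl on an aromatic carbon, ortho to a chloro group and para to a large group, gives a 1.4-fold lower number from compound 3 to compound 4 (0.15 log units; within the scatter), so at this position the two groups cannot be told apart on these readings. The earlier compounds shown here showed a stronger reading for 3-chloro-4-methylphenyl than for phenyl, and the methyl group turns out not to be needed for it: 3,4-dichlorophenyl in place of phenyl gives a 3.8-fold lower number from compound 1 to compound 4 (0.58 log units; beyond the scatter), also beyond the scatter. Exchanging cyclohexyl for 3,4-dichlorophenyl gives an at least 7.6-fold lower number from compound 2 to compound 4 (0.88 log units; beyond the scatter), which is a floor only, as the reading of compound 2 is a limit and not a number: the limit of > 40000 nM in this assay, at which 1 of the 4 values shown sits.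

The compounds shown leave open whether a group of another kind at this position, such as methoxy, trifluoromethyl or an amine, would read like chloro and methyl or differently. They also leave open whether a phenyl ring with a single chloro group would already reach the reading of compound 4, or whether both groups on the ring are required.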